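From acetyl to benzoyl: expecting compound 3

The compounds below may be only part of what the source reports. "The series", "measured", "known", "first", "only" and "open" are said of these compounds alone.

Compound 1 `C=C[C@@](C)(/C=C/c1ccc(O)c(/C=C/C(=O)c2ccccc2)c1)CCC=C(C)C` gives 4470 nM
Compound 2 `COc1ccc(/C=C/[C@@](C)(/C=C/c2ccc(O)c(/C=C/C(C)=O)c2)CCC=C(C)C)cc1` gives only a limit, > 43400 nM

In a functional assay on NALM-6 cells (Homo sapiens) for cytotoxicity, with a stated time of 72 h (on this read-out higher numbers stand for an effect only at larger amounts of compound and lower numbers for an effect already at smaller amounts), compound 1 has a measured number (4470 nM). Compound 2 stands only at a limit (> 43400 nM) and has no number on this read-out.

Compound 3 `COc1ccc(/C=C/[C@@](C)(/C=C/c2ccc(O)c(/C=C/C(=O)c3ccccc3)c2)CCC=C(C)C)cc1` differs from compound 2 by phenyl in place of methyl on a carbonyl carbon, which turns acetyl to benzoyl. Within the data shown here, no measured pair shows this change alone. Among the measured compounds shown here, compound 1 also carries benzoyl, and its value (4470 nM) is the only guide, so a step beyond the scatter towards lower numbers in this assay is expected. The estimated step runs as follows (an at least 4.8-fold lower number from compound 2 to compound 3 (0.68 log units; beyond the scatter)). For compound 3 the expected value is 9000 nM (estimated range 2500 nM to 35000 nM).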

Compound 3, half-maximal effective concentration: > 43400 nM
Compound 3 was reported as a limit; the forecaster's own chance of this, stated with the estimate: 15%; middle value at least 4.8-fold (0.68 log units) away from the limit.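

With benzoyl on the carbonyl carbon, compound 3 still does not come close to compound 1. The two share benzoyl and differ only by 2-(4-methoxyphenyl)ethenyl in place of vinyl on the saturated chain carbon, a single change that gives an at least 9.7-fold higher number from compound 1 to compound 3 (0.98 log units; beyond the scatter) in this assay and so ties the gap to that carbon, not to the carbonyl. The step between compound 2 and compound 3 cannot be read, because both stand at a limit: the limit of > 43400 nM in this assay, at which 2 of the 3 values shown sit.

On these data alone, what phenyl in place of methyl does on the carbonyl carbon therefore stays open. Also open, as far as these compounds go, is whether a smaller group such as ethyl, or a chain ending in an amine, on the saturated chain carbon would give a measured number in this assay and not a limit.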